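Methylating the amine of a weak arginine methyltransferase inhibitor

A few compounds are considered here, and "the series" means these few. Any claim that something is new, unique, unknown or untested is made for them only; others in the source may bear on it.

Measured compounds:
Compound 1, `C[C@H](N)C(=O)NCc1cccnc1Oc1ccc(F)cc1F`: 14000 nM
Compound 2, `CCC(c1ccc(OC)cc1)N(C)CCN`: > 25000 nM
Compound 3, `NCCN1CCC(c2nnc(Cn3ccnc3)n2C2CC2)CC1`: "not active" (no number reported)

Three compounds were examined in an assay on isolated protein for inhibition of protein arginine N-methyltransferase 6 (Homo sapiens); a lower number here means a stronger inhibitor, a higher number a weaker inhibitor. Among the measured compounds shown here, compound 1 is the only one with a definite number, giving 14000 nM, a weak inhibition. Compound 2 returned only a limit, > 25000 nM, so no number is known for it. Compound 3 was recorded as "not active" (no number reported) without any figure. Compound 1 therefore stands as the sole anchor on the scale, with one limit beside it and one entry without a number (the limit of > 25000 nM in this assay, at which 1 of the 3 values shown sits).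

Compound 4, `CN[C@@H](C)C(=O)NCc1cccnc1Oc1ccc(F)cc1F`, is not yet measured. It differs from compound 1 by a single change: methyl in place of hydrogen on an amine nitrogen. For the measured compounds named here, no pair of measured compounds differing in one place exists, so nothing in the data tells how this assay responds to such a change. The author expects the step in this assay to be small, within the usual scatter, with no clear direction. Compound 4 is estimated at 10000 nM, between 3000 nM and 30000 nM, which means an expected step of a 1.4-fold lower number from compound 1 to compound 4 (0.15 log units; within the scatter).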

Compound 4, half-maximal inhibitory concentration: "not active" (no number reported)
For compound 4 the study gives words and no number; the estimate stays without a comparison.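

In this assay, among the compounds shown here, compound 4 is recorded as "not active" (no number reported), so no step from compound 1 to compound 4 can be read. The compounds shown leave open how much methyl in place of hydrogen on the amine nitrogen changes inhibition.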